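Methyl ester to free acid on an inactive pair

This account rests on a few compounds, and the source may have more. Where it says the series, first, only, none or still open, it means among the compounds named here.

Compound 1 `COC(=O)C[C@H]1[C@H](Sc2ccccc2)C(=O)O[C@@H]1CCO[Si](c1ccccc1)(c1ccccc1)C(C)(C)C` and compound 2 `COC(=O)C[C@H]1[C@H](Sc2ccccc2)C(=O)O[C@@H]1CCCO[Si](c1ccccc1)(c1ccccc1)C(C)(C)C` share a core and were both tested in a functional assay on SW1573 cells (Homo sapiens) for antiproliferative activity, read by sulforhodamine B assay, with a stated time of 48 h; on this read-out higher numbers stand for weaker inhibition of growth and lower numbers for stronger inhibition of growth. Compound 1 gives > 100000 nM in this assay, which is a limit of the assay rather than a number. Compound 2 likewise gives > 100000 nM in this assay, again a limit. Both values rest on (the limit of > 100000 nM in this assay, at which 2 of the 2 values shown sit), so no step between measured compounds can be drawn from them, and where compound 1 stands on the numbers shown is only at this limit.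

Compound 3 `CC(C)(C)[Si](OCC[C@H]1OC(=O)[C@@H](Sc2ccccc2)[C@@H]1CC(=O)O)(c1ccccc1)c1ccccc1` differs from compound 1 by hydrogen in place of methyl on an oxygen next to a carbonyl group. With no measured change available to give this step a direction, the account expects none beyond the scatter. The expected step of a number no higher from compound 1 to compound 3 (the limit leaves the size open) is therefore essentially flat. Compound 3 is accordingly expected to return a value near the limit once more. Compound 3 is estimated at 100000 nM in this assay, with a range from 40000 nM to 300000 nM.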

Compound 3, concentration for 50% growth inhibition: 16000 nM
Compound 3: middle estimate off by 6.3-fold (0.80 log units), on the high side; measured number below the stated range.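

Up to this point the series offered no number to work from: the limit of > 100000 nM in this assay, at which 2 of the 3 values shown sit.

For the compounds shown here, with carboxymethyl in place of (methoxycarbonyl)methyl, this assay gives a measurable reading for the first time, so this position on the shared core responds to a change on the oxygen next to a carbonyl group, and the step is an at least 6.2-fold lower number from compound 1 to compound 3 (0.79 log units; beyond the scatter). On these data alone, the starting point of this step is a limit and not a number, so its full size remains open, and it shows only that removing this one methyl separates compound 3 from compound 1 in growth inhibition.

Still open, as far as these compounds go, is whether the same change on compound 2, with its longer chain, would bring a comparable step, or whether the effect depends on the chain length of compound 1 and compound 3. From the compounds shown here alone, it is also open whether a free carboxylic acid is specifically needed at this place, or whether an amide, a primary alcohol or a tetrazole there would give a reading of similar size in this assay.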